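Side-Chain Swaps and a Hydroxymethyl Addition on a Shared Core

The compounds below may be only part of what the source reports. "The series", "measured", "known", "first", "only" and "open" are said of these compounds alone.

- Compound 1 `CC(C)Cn1cc(C(=O)O)c(=O)c2c(O)c(Cc3cccc(Cl)c3F)ccc21`: 19500 nM
- Compound 2 `CCC(C)n1cc(C(=O)O)c(=O)c2c(O)c(Cc3cccc(Cl)c3F)ccc21`: 30700 nM
- Compound 3 `O=C(O)c1cn(C2CCCC2)c2ccc(Cc3cccc(Cl)c3F)c(O)c2c1=O`: 12400 nM

These three compounds were tested in an ADME assay on C8166 cells (Homo sapiens) for cytotoxicity, read by MTT assay; a higher number here means that more compound is tolerated, a lower number that less compound is tolerated. They share one core and differ only in the group on the aromatic nitrogen. Compound 1 lies within the scatter of both others, with a 1.6-fold higher number from compound 1 to compound 2 (0.20 log units; within the scatter) and a 1.6-fold lower number from compound 1 to compound 3 (0.20 log units; within the scatter). Only a 2.5-fold lower number from compound 2 to compound 3 (0.39 log units; beyond the scatter) goes past the scatter.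

Compound 4 `CC(C)[C@@H](CO)n1cc(C(=O)O)c(=O)c2c(O)c(Cc3cccc(Cl)c3F)ccc21` changes that same group, and the change is hydroxymethyl in place of hydrogen on a saturated chain carbon bound to an aromatic nitrogen and a saturated chain carbon. This turns isobutyl into 1-(hydroxymethyl)-2-methylpropyl. The three measured steps alter the group at that nitrogen, so they bear on this change. None of their groups carries a hydroxymethyl. They suggest a small size and no firm direction, so no step beyond the scatter is expected in this assay. The estimated step is a 1.3-fold higher number from compound 1 to compound 4 (0.11 log units; within the scatter). Compound 4 is estimated at 25000 nM, with an expected range of 10000 nM to 70000 nM.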

Compound 4, half-maximal cytotoxic concentration: 125000 nM
The estimate for compound 4 lay 5.0-fold (0.70 log units) below the measured number; the measured number lies above the stated range.
By their numbers in this assay, from the lowest: compounds 3, 1 and 2 (each within the scatter of the next, the first and the last beyond it); then compound 4.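

In this assay, the group on the aromatic nitrogen can shift the number well beyond the scatter: hydroxymethyl in place of hydrogen on the saturated chain carbon gives a 6.4-fold higher number from compound 1 to compound 4 (0.81 log units; beyond the scatter), a larger step than any among compounds 1, 2 and 3. Compound 4 also stands clear of the other two, with a 10-fold higher number from compound 3 to compound 4 (1.00 log units; beyond the scatter) and a 4.1-fold higher number from compound 2 to compound 4 (0.61 log units; beyond the scatter), so it has the highest number of the four. No measurement shown offers an explanation for this large step.

The compounds shown leave open whether the step needs the hydroxymethyl itself, or whether a methyl, a methoxymethyl or an aminomethyl on that same chain carbon would give a similar number. They also leave open how the mirror-image form of compound 4 would compare.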